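Swapping the ring substituent on the arylpiperazine: compound 4

The compounds below may be only part of what the source reports. "The series", "measured", "known", "first", "only" and "open" are said of these compounds alone.

Measured in a functional assay on aorta for antagonist activity at Alpha-1D adrenergic receptor (Rattus norvegicus); a higher number here means weaker binding, a lower number tighter binding:
- compound 1, `Cc1ccccc1N1CCN(CCCNc2ncccc2C(=O)N(C)C)CC1`: 10 nM
- compound 2, `CCCc1ccccc1N1CCN(CCCNc2ncccc2C(=O)N(C)C)CC1`: 31.6 nM
- compound 3, `CC(C)c1ccccc1N1CCN(CCCNc2ncccc2C(=O)N(C)C)CC1`: 63.1 nM

Compound 3 gives the highest number of the three in this assay; the gap to compound 2 is within the scatter, the gap to compound 1 beyond it. The step from compound 3 to compound 4, `COc1cc(O)ccc1N1CCN(CCCNc2ncccc2C(=O)N(C)C)CC1`, is 4-hydroxy-2-methoxyphenyl in place of 2-isopropylphenyl on an amine nitrogen in a ring. Within the data shown here, no measured step exchanges an alkyl for an oxygen-bearing substituent, so none bears on it directly. Among the measured compounds shown here, the steps in hand, a 3.2-fold higher number from compound 1 to compound 2 (0.50 log units; beyond the scatter) and a 6.3-fold higher number from compound 1 to compound 3 (0.80 log units; beyond the scatter), show only that enlarging the alkyl group on the phenyl raises the number; a 2.0-fold higher number from compound 2 to compound 3 (0.30 log units; within the scatter) adds nothing beyond the scatter. For the measured compounds named here, compound 4 carries no alkyl at all, and the hydroxy and methoxy have no precedent here. The expectation for compound 4 is therefore a number somewhere between those of compound 1 and compound 3, a step of a 2.5-fold lower number from compound 3 to compound 4 (0.40 log units; beyond the scatter), held with low confidence. The estimate for compound 4 in this assay is 25 nM, within 5 nM to 125 nM.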

Compound 4, dissociation constant: 79.4 nM
The estimate for compound 4 lay 3.2-fold (0.50 log units) below the measured number, within the range that was stated.
By their numbers in this assay, from the lowest: compound 1; then compounds 2, 3 and 4 (each within the scatter of the next, the first and the last beyond it).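

With a 1.3-fold higher number from compound 3 to compound 4 (0.10 log units; within the scatter) in this assay, 4-hydroxy-2-methoxyphenyl, which has no alkyl group and brings a hydrogen-bond donor and acceptors, cannot be told apart from 2-isopropylphenyl on this amine nitrogen in a ring. The same group shows a 2.5-fold higher number from compound 2 to compound 4 (0.40 log units; beyond the scatter) and also a 7.9-fold higher number from compound 1 to compound 4 (0.90 log units; beyond the scatter) as its steps, so a high number at this position is not tied to a larger alkyl group, and 2-methylphenyl still gives the lowest number of the four. No measurement here accounts for these steps.

The compounds shown leave open whether the hydroxy, the methoxy or the two together set the number. A 2-methoxyphenyl or a 4-hydroxyphenyl group on the same nitrogen would separate the two contributions.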